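Cyclopropyl for tert-Butyl on a Phenol Core

The source may hold more compounds than are shown below. What is called first, only, known or untested is meant among the compounds shown, and "the series" means these compounds.

Compound 1 `N#Cc1cc(C(=O)N2CCc3ccccc32)ccc1O` carries the shared core with a hydrogen on the aromatic carbon in question. In an assay on tissue (RPTEC cells) for inhibition of solute carrier family 22 member 12 (Homo sapiens), read by scintillation counting, with stated times of 15 min and 2 h (a lower number here means a stronger inhibitor, a higher number a weaker inhibitor), compound 1 gives 2500 nM. Compound 2 `CSc1cc(C(=O)N2CCc3ccccc32)cc(C#N)c1O` bears a methylsulfanyl there; in this assay compound 2 reaches > 100000 nM, which is a limit of the assay and not a number (the limit of > 100000 nM in this assay, at which 1 of the 3 values shown sits). Compound 3 `CC(C)(C)c1cc(C(=O)N2CCc3ccccc32)cc(C#N)c1O` has a tert-butyl at that carbon; in this assay compound 3 gives 31600 nM, the highest of the two numbers shown, with compound 1 as its nearest neighbour. The measured steps are an at least 40-fold higher number from compound 1 to compound 2 (1.60 log units; beyond the scatter), a 13-fold higher number from compound 1 to compound 3 (1.10 log units; beyond the scatter) and an at least 3.1-fold lower number from compound 2 to compound 3 (0.50 log units; beyond the scatter).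

Compound 4 `N#Cc1cc(C(=O)N2CCc3ccccc32)cc(C2CC2)c1O` is not yet measured. It differs from compound 3 by cyclopropyl in place of tert-butyl on an aromatic carbon. For the measured compounds named here, the steps that bear on this change are a 13-fold higher number from compound 1 to compound 3 (1.10 log units; beyond the scatter) and an at least 3.1-fold lower number from compound 2 to compound 3 (0.50 log units; beyond the scatter), both large. The change removes the tert-butyl but does not restore the hydrogen of compound 1, so only part of the step of a 13-fold higher number from compound 1 to compound 3 (1.10 log units; beyond the scatter) is expected to be undone, and a modest downward step, a 2.1-fold lower number from compound 3 to compound 4 (0.32 log units; beyond the scatter), is expected in this assay. For compound 4 the estimate in this assay is 15000 nM, expected to fall between 4000 nM and 60000 nM.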

Compound 4, half-maximal inhibitory concentration: 8800 nM
The estimate for compound 4 lay 1.7-fold (0.23 log units) above the measured number, and the stated range covers the measured number.
By their numbers in this assay, from the lowest: compound 1; then compound 4; then compound 3. At a limit, above all of these: compound 2.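

In this assay, the carbon ortho to a hydroxy group proves able to tell two carbon groups apart, with cyclopropyl in place of tert-butyl giving a 3.6-fold lower number from compound 3 to compound 4 (0.56 log units; beyond the scatter), yet cyclopropyl does not match the hydrogen, with a 3.5-fold higher number from compound 1 to compound 4 (0.55 log units; beyond the scatter). Cyclopropyl also reads far lower than methylsulfanyl, with an at least 11-fold lower number from compound 2 to compound 4 (1.05 log units; beyond the scatter), so each of the three groups shown at this carbon gives a higher number than hydrogen, and they differ widely among themselves. Compound 2 stands at a limit of the assay and not at a number: the limit of > 100000 nM in this assay, at which 1 of the 4 values shown sits.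

The compounds shown leave open whether a methyl, a methoxy group, a chlorine or an amine on this carbon would come as close to compound 1 as cyclopropyl does, or closer, and so whether any group at this place can equal or pass the hydrogen. They also leave open whether the order seen here would hold with the cyano group or the hydroxy group replaced, since all four compounds carry both, and no reason for the order can be drawn from these numbers.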